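The compounds below may be only part of what the source reports. "The series", "measured", "known", "first", "only" and "open" are said of these compounds alone.

Compound 1, `CCCNS(=O)(=O)c1ccc(Nc2ncc3c(n2)N(C2CCCC2)[C@H](CC)C(=O)N3C)cc1`, gives 17.8 nM.
Compound 2, `CCC1C(=O)N(C)c2cnc(-n3ccc4cc(C(=O)NCC(C)C)ccc43)nc2N1c1ccn(C)n1`, gives 159 nM.

In an assay for inhibition of serine/threonine-protein kinase PLK2 (Homo sapiens), read by FRET and Z'-LYTE, with a stated time of 1 h (a lower number here means a stronger inhibitor, a higher number a weaker inhibitor), compound 1 holds the lowest of the two numbers, and the gap to compound 2 lies beyond the usual scatter of repeat measurements. Compound 3, `CC[C@@H]1C(=O)N(C)c2cnc(Nc3ccc(S(=O)(=O)NCC(C)C)cc3)nc2N1C1CCCC1`, has not yet been measured. It differs from compound 1 in a single place: methyl in place of hydrogen on a saturated chain carbon bound to two saturated chain carbons. Going by the values given here, no measured pair shows what this change does, so the step of a 1.1-fold higher number from compound 1 to compound 3 (0.05 log units; within the scatter) is expected to be small, in no clear direction, and to stay within the scatter. Compound 3 is therefore estimated at 20 nM, with a range from 8 nM to 50 nM.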

Compound 3, half-maximal inhibitory concentration: 21.8 nM
Estimate against measurement, compound 3: 1.1-fold (0.04 log units) below; the measured number falls inside the stated range.
By their numbers in this assay, from the lowest: compounds 1 and 3 (each within the scatter of the next); then compound 2.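

In this assay, exchanging propyl for isobutyl, which places a methyl in place of hydrogen on a saturated chain carbon bound to two saturated chain carbons, gives a 1.2-fold higher number from compound 1 to compound 3 (0.09 log units; within the scatter). Going by these compounds alone, this chain therefore accepts one added methyl with no readable change in this measurement, something the earlier compounds could not show. Nothing measured here explains this result.

The compounds shown leave open how far this tolerance extends. A longer chain such as hexyl, or a chain carrying an amine or a carboxylic acid, could behave differently in place of isobutyl.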